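Sulfonyl to Sulfanyl Exchange on a Weak Growth Inhibitor

A few compounds are considered here, and "the series" means these few. Any claim that something is new, unique, unknown or untested is made for them only; others in the source may bear on it.

Compound 1 `CCOc1ccc(/C=C(\C(=O)c2ccc(Cl)cc2)S(=O)(=O)Cc2ccc(F)cc2)cc1OC` gives 50000 nM in a functional assay on DU-145 cells (Homo sapiens) for inhibition, read by trypan blue exclusion, with a stated time of 96 h; a higher number here means a weaker inhibitor of growth, a lower number a stronger inhibitor of growth. Compound 3 `O=C(/C(=C\c1c[nH]c2ccccc12)S(=O)(=O)Cc1ccc(F)cc1)c1ccc(Cl)cc1` gives 50000 nM in this assay, and no change at the digits printed from compound 1 to compound 3 (within the scatter). Compound 2 `O=C(/C(=C\c1ccc(Br)cc1)S(=O)(=O)Cc1ccc(F)cc1)c1ccc(Cl)cc1` reaches only a limit, > 100000 nM, in this assay. Accordingly an at least 2.0-fold higher number from compound 1 to compound 2 (0.30 log units; that floor lies within the scatter), and an at least 2.0-fold lower number from compound 2 to compound 3 (0.30 log units; that floor lies within the scatter). Compound 1 thus stands level with compound 3, while compound 2 is known only through (the limit of > 100000 nM in this assay, at which 1 of the 3 values shown sits). Compound 4 `CCOc1ccc(/C=C(/SCc2ccc(Cl)c(Cl)c2)C(=O)c2ccc(Cl)cc2)cc1OC` differs from compound 1 elsewhere: (3,4-dichlorobenzyl)sulfanyl in place of (4-fluorobenzyl)sulfonyl on a double-bonded chain carbon bound to a carbonyl carbon and a double-bonded chain carbon. Every measured step alters the group on a double-bonded chain carbon bound to a double-bonded chain carbon and leaves the (4-fluorobenzyl)sulfonyl untouched, so none of them bears on this change. Compound 4 is therefore expected close to compound 1, a 1.3-fold lower number from compound 1 to compound 4 (0.10 log units; within the scatter), with a broad range. The estimate for compound 4 is 40000 nM, between 8000 nM and 100000 nM.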

Compound 4, concentration for 50% growth inhibition: 25000 nM
Compound 4: middle estimate off by 1.6-fold (0.20 log units), on the high side; the range from low to high includes it.
By their numbers in this assay, from the lowest: compounds 4, 1 and 3 (each within the scatter of the next). At a limit, above all of these: compound 2.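

In this assay, the first change measured on the double-bonded chain carbon bound to a carbonyl carbon and a double-bonded chain carbon gives a 2.0-fold lower number from compound 1 to compound 4 (0.30 log units; within the scatter). Going by these compounds alone, the sulfonyl link and the ring halogens change together in this step, so it shows only that this combined exchange stays within the scatter on the core of compound 1. Nothing measured here offers a cause for this step.

The compounds shown leave open what (4-fluorobenzyl)sulfanyl or (3,4-dichlorobenzyl)sulfonyl would give alone. They also leave open how an amine or a carboxylic acid on the benzyl ring would read in this assay.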